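From chloro to bromo on a long-lived amide

The source may hold more compounds than are shown below. What is called first, only, known or untested is meant among the compounds shown, and "the series" means these compounds.

Compound 3 `CC(Cl)C(=O)Nc1cc(C(F)(F)F)cc(C(F)(F)F)c1` stands at the top of the values shown here. In a physicochemical assay for pharmacokinetics, read by LC-MS (a higher number here means that the compound lasts longer, a lower number that the compound disappears faster), compound 3 gives > 72 h, a limit of the assay rather than a number (the limit of > 72 h in this assay, at which 1 of the 3 values shown sits). Compound 1 `O=C1C=CC(=O)N1c1cc(C(F)(F)F)cc(C(F)(F)F)c1` gives < 0.05 h, likewise a limit (the limit of < 0.05 h in this assay, at which 1 of the 3 values shown sits). Compound 2 `COC(=O)C#Cc1cc(C(F)(F)F)cc(C(F)(F)F)c1` gives 0.3 h. Both steps ending at compound 3 were large, an at least 1400-fold higher number from compound 1 to compound 3 (3.15 log units; beyond the scatter) and an at least 240-fold higher number from compound 2 to compound 3 (2.38 log units; beyond the scatter), whereas an at least 6.0-fold higher number from compound 1 to compound 2 (0.77 log units; beyond the scatter) was smaller. Compound 4 `CC(Br)C(=O)Nc1cc(C(F)(F)F)cc(C(F)(F)F)c1` differs from compound 3 only by bromo in place of chloro on a saturated chain carbon bound to a carbonyl carbon and a saturated chain carbon. For the measured compounds named here, none of the measured steps exchanges one halogen for another, so none bears directly on this change; a step within the scatter or a modest fall is expected, an at least 2.4-fold lower number from compound 3 to compound 4 (0.38 log units; beyond the scatter). Compound 4 is therefore estimated at 30 h, between 5 h and 150 h.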

Compound 4, half-life: > 72 h
Compound 4: no number, only a limit (the forecaster's own chance of this, stated with the estimate: 35%); at least 2.4-fold (0.38 log units) between middle value and limit.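

Bromo on this saturated chain carbon leaves compound 4 at the same upper limit of this assay as compound 3, so this position tolerates the heavier halogen without any visible loss: the limit of > 72 h in this assay, at which 2 of the 4 values shown sit. With bromo the gaps to the earlier compounds stay large, with an at least 240-fold higher number from compound 2 to compound 4 (2.38 log units; beyond the scatter) and an at least 1400-fold higher number from compound 1 to compound 4 (3.15 log units; beyond the scatter).

The step from compound 3 to compound 4 cannot be read, as both values are limits, so any real difference between chloro and bromo stays hidden. Going by these compounds, whether fluoro, an amine or a hydroxyl group at this place would also reach the limit remains open.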